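The source may report more compounds than this note shows. Statements on the series, on what has been measured and on what is new or still open speak of the compounds shown alone.

Measured so far: compound 1 `c1ccc(-c2cn3ccnc3c(-c3ccc4ncn(C5CCCCC5)c4c3)n2)cc1` with 55.2% in a functional assay on UO-31 cells (Homo sapiens) for inhibition, read by sulforhodamine B assay, with a stated time of 48 h, tested at 10 uM (on this read-out higher numbers stand for more inhibition at the one concentration tested (going by the name of the read-out) and lower numbers for less inhibition), and compound 2 `O=Cc1ccc(-c2cn3ccnc3c(-c3ccc4ncn(C5CCCCC5)c4c3)n2)cc1` with 82.2% in this assay.

Within the data shown here, compound 2 stands highest of the two numbers, separated from its only neighbour by a number 27 percentage points higher from compound 1 to compound 2 (beyond the scatter). Among the measured compounds shown here, compound 3 `c1cn2cc(-c3ccsc3)nc(-c3ccc4ncn(C5CCCCC5)c4c3)c2n1` is not yet measured. thiophen-3-yl in place of 4-formylphenyl on an aromatic carbon The one step that bears on this change is a number 27 percentage points higher from compound 1 to compound 2 (beyond the scatter), where a formyl entered; compound 3 carries no formyl, so the expected step is a fall, a number 27.2 percentage points lower from compound 2 to compound 3 (beyond the scatter), back toward the level of compound 1. Compound 3 is therefore estimated at 55%, with a range from 35% to 75%.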

Compound 3, a percentage reported as inhibition, at one concentration (the size of the read-out at that concentration, not a potency): 23.1%
Beside the measured number, compound 3's estimate is 31.9 percentage points above it, outside the stated range (below it).
By their numbers in this assay, from the lowest: compound 3; then compound 1; then compound 2.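

In this assay this position can fall below the level of the plain phenyl: thiophen-3-yl in place of 4-formylphenyl gives a number 59.1 percentage points lower from compound 2 to compound 3 (beyond the scatter) and thiophen-3-yl in place of phenyl gives a number 32.1 percentage points lower from compound 1 to compound 3 (beyond the scatter) as well. The absence of the formyl therefore does not by itself describe the result, since the ring carrying it also matters at this position. Nothing measured here explains the fall.

On these data alone, whether a hydroxymethyl or a carboxylic acid in place of the formyl would hold the higher level stays open. So does whether a formyl on the thiophene would restore it.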